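The compounds below may be only part of what the source reports. "The series", "measured", "known", "first", "only" and "open" are said of these compounds alone.

Compound 1, `O=C(c1sc2c([N+](=O)[O-])cc(C(F)(F)F)cc2[n+]1[O-])N1CCCCC1`, is the better characterised of the two measured compounds: in an ADME assay on A549 cells (Homo sapiens) for cytotoxicity, read by fluorescence, with a stated time of 72 h (a lower number here means a stronger inhibitor, a higher number a weaker inhibitor), compound 1 gives 24000 nM. Compound 2, `Cc1c(C(F)(F)F)cc2nc(C3=N[C@H](C(=O)N4CCCC4)CO3)sc2c1[N+](=O)[O-]`, carries a methyl on the shared core that compound 1 lacks, together with a different amide portion, so the two cannot be compared by a single change. For compound 2 the assay reports only a limit, > 100000 nM, the edge of what it can resolve, as described by the limit of > 100000 nM in this assay, at which 1 of the 2 values shown sits. Compound 3, `O=C([C@@H]1COC(c2nc3cc(C(F)(F)F)cc([N+](=O)[O-])c3s2)=N1)N1CCCC1`, differs from compound 2 in one place: hydrogen in place of methyl on an aromatic carbon. For the measured compounds named here, no measured pair shows what removing a methyl at such a position does here, so the size of the step is unknown; one small carbon leaving is expected to move the reading little, if at all, beyond the scatter. Compound 3 is therefore expected to sit near the limit, at about 100000 nM, within a range of 30000 nM to 300000 nM, an expected step of a number no higher from compound 2 to compound 3 (the limit leaves the size open).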

Compound 3, half-maximal inhibitory concentration in the A549 assay: 82000 nM
Compound 3: middle estimate off by 1.2-fold (0.09 log units), on the high side, and the stated range covers the measured number.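

In the A549 assay, hydrogen in place of methyl on this aromatic carbon, ortho to a nitro group and ortho to a trifluoromethyl group, gives an at least 1.2-fold lower number from compound 2 to compound 3 (0.08 log units; that floor lies within the scatter), the first step read at this position. That step is only a floor, since the reading for compound 2 is a limit and not a number: the limit of > 100000 nM in the A549 assay, at which 1 of the 3 values shown sits. In a physicochemical assay for solubility (a lower number here means a less soluble compound, a higher number a more soluble compound), compound 2 gives 12000 nM and compound 3 gives 64600 nM, so the loss of the methyl goes with a clear gain in solubility: the measured solubility of compound 2, 12000 nM, and of compound 3, 64600 nM, a 5.4-fold higher number (0.73 log units; beyond the scatter).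

On these data alone, only methyl and hydrogen appear at this position, so what an amine or a methoxy group there would do in either the A549 assay or the physicochemical assay stays open. As far as these compounds go, whether the solubility gain would hold with another amide portion also stays open.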